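A few compounds are considered here, and "the series" means these few. Any claim that something is new, unique, unknown or untested is made for them only; others in the source may bear on it.

In an ADME assay on Huh-7 cells (Homo sapiens) for cytotoxicity (on this read-out higher numbers stand for lower toxicity in this test and lower numbers for higher toxicity in this test), compound 1, `CN1CCN(CCNCc2cn(-c3ccc(F)cc3F)nc2-c2ccc(Cl)cc2)CC1`, gives 19000 nM. Compound 2, `Cc1ccccc1-c1nn(-c2ccc(F)cc2F)cc1CNC1CCN(S(C)(=O)=O)CC1`, reaches only the limit of the measurement, > 20000 nM. Compound 3, `COc1ccc(-n2cc(CNCCN3CCN(C)CC3)c(-c3ccccc3C)n2)cc1`, likewise stops at the limit of the measurement, > 20000 nM. Compound 3 thus stands among the two of three values that sit at the limit of > 20000 nM in this assay, at which 2 of the 3 values shown sit, and no number for it is known, only that limit. Compound 4, `Cc1ccc(-n2cc(CNCCN3CCN(C)CC3)c(-c3ccccc3C)n2)c(C)c1`, differs from compound 3 by 2,4-dimethylphenyl in place of 4-methoxyphenyl on an aromatic nitrogen. Within the data shown here, no pair of measured compounds here differs in a single place, so no measured step guides the expectation. Compound 4 is expected to remain in the same region as compound 3, with a step of a number no higher from compound 3 to compound 4 (the limit leaves the size open) that lies within the scatter of this assay, and compound 4 is estimated at 20000 nM, between 8000 nM and 40000 nM.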

Compound 4, half-maximal cytotoxic concentration: > 20000 nM
Compound 4: no number, only a limit; the forecaster's own chance of this, stated with the estimate: 60%; the middle value lies on the limit itself.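

The step between compound 3 and compound 4 cannot be read, since both values are limits rather than numbers: the limit of > 20000 nM in this assay, at which 3 of the 4 values shown sit.

The compounds shown leave open how far either true value lies past that limit, and whether 2,4-dimethylphenyl in place of 4-methoxyphenyl makes any difference in this assay.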